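Sulfur aryl exchange from compound 2 to compound 3

A few compounds are considered here, and "the series" means these few. Any claim that something is new, unique, unknown or untested is made for them only; others in the source may bear on it.

Compound 1 `Cc1cc(C)cc(SCc2ccc(/C=C/C(=O)Nc3ccccc3N)cc2)c1` and compound 2 `Nc1ccccc1NC(=O)/C=C/c1ccc(CSc2ccc(C(F)(F)F)cn2)cc1` share one core and differ only in the group on the sulfur. In a functional assay on SMMC-7721 cells (Homo sapiens) for inhibition, read by CCK-8 assay, with a stated time of 72 h, tested at 2 uM (a lower number here means less inhibition of growth, a higher number more inhibition of growth at the concentration tested), compound 1 gives 8.61% of growth inhibition. Within the data shown here, compound 2 gives 12.1% of growth inhibition in the same read-out, which places it within the scatter of the only other number.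

The next compound is compound 3 `Nc1ccccc1NC(=O)/C=C/c1ccc(CSc2ccc(F)cc2)cc1` with 4-fluorophenyl in place of 5-(trifluoromethyl)pyridin-2-yl on a sulfur and the core unchanged.

Among the measured compounds shown here, only one measured step bears on this exchange: a number 3.5 percentage points higher from compound 1 to compound 2 (within the scatter) at the same sulfur, also between two groups with a six-membered aromatic ring. For the measured compounds named here, one step is thin evidence, and no measured compound yet carries the 4-fluorophenyl group. No step beyond the scatter is therefore expected in this assay and neither direction is favoured. The expected move is a number 1.1 percentage points lower from compound 2 to compound 3 (within the scatter) and it is not expected to leave the scatter. Compound 3 is estimated at 11% with an expected range of 3% to 24% in repeat measurements.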

Compound 3, percent growth inhibition at one concentration: 18.3%
For compound 3 the middle estimate is 7.3 percentage points below the measured one; the range from low to high includes it.
By their numbers in this assay, from the lowest: compounds 1, 2 and 3 (each within the scatter of the next).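

In this assay, 4-fluorophenyl in place of 5-(trifluoromethyl)pyridin-2-yl on the sulfur gives a number 6.2 percentage points higher from compound 2 to compound 3 (within the scatter), and 4-fluorophenyl in place of 3,5-dimethylphenyl at the same place gives a number 9.7 percentage points higher from compound 1 to compound 3 (within the scatter). Among these compounds, the sulfur now carries three different six-membered aromatic rings, two of carbon only and one with a hetero atom, and no step among them leaves the scatter, so this assay separates neither the two ring types nor the two substitution patterns on the carbon rings, nor the 10-heavy-atom group from the 7-heavy-atom one. No measurement on hand offers an explanation for the numbers of this set.

Open is whether any group on the sulfur moves the number beyond the scatter, since all three groups shown are six-membered aromatic rings: a saturated cyclohexyl ring, a short alkyl chain, or a phenyl ring carrying a carboxylic acid or an amine would test that. Also open, going by these compounds, is whether the sulfur itself matters, which an oxygen or a methylene in its place would address, and whether these compounds can be ranked at all from a read-out at a single concentration.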